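Replacing methoxy with isopropylamino on the shared core

The compounds below may be only part of what the source reports. "The series", "measured", "known", "first", "only" and "open" are said of these compounds alone.

In a functional assay on CCRF-CEM cells (Homo sapiens) (a lower number here means a stronger inhibitor, a higher number a weaker inhibitor), compound 1 `OC[C@H]1C[C@@H](Cn2cnc3c(Cl)ncnc32)c2ccccc21` gives 24 ug/mL, compound 2 `OC[C@H]1C[C@@H](Cn2cnc3c(O)ncnc32)c2ccccc21` gives 24 ug/mL and compound 3 `COc1ncnc2c1ncn2C[C@@H]1C[C@H](CO)c2ccccc21` gives 24 ug/mL, so compound 3 stands level with both. Compound 4 `CC(C)Nc1ncnc2c1ncn2C[C@@H]1C[C@H](CO)c2ccccc21` keeps the shared core but carries isopropylamino in place of methoxy on an aromatic carbon. Three measured swaps of groups on an aromatic carbon bear on this change: no change at the digits printed from compound 1 to compound 2 (within the scatter), no change at the digits printed from compound 1 to compound 3 (within the scatter) and no change at the digits printed from compound 2 to compound 3 (within the scatter). None of them tested an isopropylamino group, so this guide is limited. On that evidence, the expected change in this assay stays within the scatter, with no direction favoured: a 1.1-fold lower number from compound 3 to compound 4 (0.04 log units; within the scatter). For compound 4 the estimated value is 22 ug/mL, with an expected range of 10 ug/mL to 40 ug/mL.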

Compound 4, half-maximal inhibitory concentration: 24 ug/mL
Beside the measured number, compound 4's estimate is 1.1-fold (0.04 log units) below it, within the range that was stated.
By their numbers in this assay, from the lowest: compounds 1, 2, 3 and 4 (each within the scatter of the next).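

In this assay isopropylamino, the only amine at this position among these compounds, brings 4 heavy atoms and 1 hydrogen-bond donor, yet the result is no change at the digits printed from compound 3 to compound 4 (within the scatter). Against the other two groups the result is no change at the digits printed from compound 2 to compound 4 (within the scatter) and no change at the digits printed from compound 1 to compound 4 (within the scatter). Across these four compounds, then, a branched amine joins chloro, hydroxy and methoxy in giving the same printed value on this aromatic carbon.

On these data alone, whether a carboxylic acid or a longer chain here would shift the number remains open. No available evidence accounts for this flat result.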